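Shortening the Selenocyanate Tether in Compound 2

The source may report more compounds than this note shows. Statements on the series, on what has been measured and on what is new or still open speak of the compounds shown alone.

Three measured compounds share one core. Compound 1 `C[Se]c1ccc(N(C)c2nc(C3CC3)nc3ccccc23)cc1` gives 11 nM in a functional assay on LoVo cells (Homo sapiens) for inhibition, read by MTT assay, with a stated time of 48 h; a higher number here means a weaker inhibitor, a lower number a stronger inhibitor. Compound 3 `Cc1nc(N(C)c2ccc([Se]C#N)c(F)c2)c2ccccc2n1` gives 13 nM in this assay. Compound 2 `COc1ccc(N(C)c2nc(C)nc3ccccc23)cc1OCCCCC[Se]C#N` gives 5210 nM in this assay, the highest of the three numbers; its nearest neighbour is compound 3 and its furthest is compound 1, and both gaps lie beyond the scatter.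

Compound 4 `COc1ccc(N(C)c2nc(C)nc3ccccc23)cc1C[Se]C#N` is not yet measured. It differs from compound 2 in one place: a group of 4 heavy atoms (2 carbon, 1 nitrogen, 1 selenium; no ring) in place of a group of 9 heavy atoms (6 carbon, 1 nitrogen, 1 oxygen, 1 selenium; no ring), on an aromatic carbon. In compound 1 and compound 3 the selenium is bound directly to the aromatic ring, and both give low numbers, whereas in compound 2 it hangs at the end of a long chain. Compound 4 carries its selenium far closer to the ring than compound 2 does. Within the data shown here, no step between measured compounds is available, so the expectation rests on the values of compound 1 and compound 3 set against compound 2. Compound 4 is expected to give a lower number than compound 2, a step of a 10-fold lower number from compound 2 to compound 4 (1.02 log units; beyond the scatter), beyond the scatter. The estimate for compound 4 in this assay is 500 nM, with a range from 80 nM to 3000 nM.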

Compound 4, half-maximal inhibitory concentration: 277 nM
Estimate against measurement, compound 4: 1.8-fold (0.26 log units) above, within the range that was stated.
By their numbers in this assay, from the lowest: compounds 1 and 3 (each within the scatter of the next); then compound 4; then compound 2.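

In this assay, putting the group of 4 heavy atoms in place of the group of 9 heavy atoms on this aromatic carbon, ortho to a methoxy group, gives a 19-fold lower number from compound 2 to compound 4 (1.27 log units; beyond the scatter), a large step. Among these compounds, this is the first comparison here between compounds that differ in one place, and it shows directly that the number is sensitive to the group carried at this position. The leaving group differs from the entering group in both its chain and its oxygen, so the step cannot be divided between those two changes, and nothing shown gives a measured reason for it.

The compounds shown leave open how the number runs for chains of intermediate length ending in the same selenium and nitrile. They also leave open whether selenium is needed at this carbon, for example whether a cyanomethyl group would give a similar number.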